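The source may report more compounds than this note shows. Statements on the series, on what has been measured and on what is new or still open speak of the compounds shown alone.

Measured so far:
compound 1 `COc1ccc(/C=C/c2cc(OC)cc(OC)c2/C=C/C(=O)N2CCCCC2)cc1` — 10600 nM
compound 2 `COc1ccc(/C=C/c2cc(OC)cc(OC)c2/C=C/C(=O)NC(C)C)cc1` — 2360 nM

In a functional assay on A549 cells (Homo sapiens) for inhibition, read by MTT assay, with a stated time of 48 h (a lower number here means a stronger inhibitor, a higher number a weaker inhibitor), compound 1 gives 10600 nM, the highest of the two numbers; compound 2 gives 2360 nM, and they are separated by a 4.5-fold lower number from compound 1 to compound 2 (0.65 log units; beyond the scatter). Compound 3 `COc1ccc(/C=C/c2cc(OC)cc(OC)c2/C=C/C(=O)N2CCCC(C)C2)cc1` differs from compound 1 by methyl in place of hydrogen on a saturated ring carbon. Within the data shown here, the one measured step exchanges the whole amide substituent, so it does not bear on a methyl added to the saturated ring; no measured step of that kind exists. Compound 3 is therefore expected to stay close to compound 1, with a change of a 1.1-fold lower number from compound 1 to compound 3 (0.03 log units; within the scatter) at most, not beyond the scatter. The estimate for compound 3 is 10000 nM, between 4000 nM and 25000 nM.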

Compound 3, half-maximal inhibitory concentration: 5820 nM
The estimate for compound 3 lay 1.7-fold (0.24 log units) above the measured number; the measured number falls inside the stated range.
By their numbers in this assay, from the lowest: compound 2; then compounds 3 and 1 (each within the scatter of the next).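

In this assay, methyl in place of hydrogen on a saturated ring carbon, two ring bonds from the ring nitrogen, gives a 1.8-fold lower number from compound 1 to compound 3 (0.26 log units; within the scatter), so at this position the added methyl leaves the number within the scatter of the unsubstituted ring. With the methyl in place, the ring amide still does not match the isopropylamino amide, as a 2.5-fold higher number from compound 2 to compound 3 (0.39 log units; beyond the scatter) shows. Nothing available here bears on the reason for either step. The compounds shown leave open whether an ethyl group, a hydroxyl group or an amine at this same ring carbon would move the number beyond the scatter. They also leave open what a methyl on another carbon of this ring would do.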